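From phenyl to 4-chlorophenyl: a step from the limit

The compounds below may be only part of what the source reports. "The series", "measured", "known", "first", "only" and "open" are said of these compounds alone.

Compound 1 `CN(C)c1ccc(NC(=O)c2ncc(-c3ccccc3)o2)cc1`: > 30000 nM
Compound 2 `O=C(c1ncc(-c2ccccc2)o1)N1CCN(c2ccccc2)CC1`: > 30000 nM

In a functional assay on A549 cells (Homo sapiens) for cytotoxicity, read by CCK-8 assay (a lower number here means a stronger inhibitor, a higher number a weaker inhibitor), compound 2 gives > 30000 nM, which is a limit and not a number. Compound 1 gives > 30000 nM, which is also a limit. The whole picture so far is the limit of > 30000 nM in this assay, at which 2 of the 2 values shown sit. Among the measured compounds shown here, no measured step yet shows what a single structural change does.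

Compound 3 `O=C(c1ncc(-c2ccccc2)o1)N1CCN(c2ccc(Cl)cc2)CC1` differs from compound 2 in one place: chloro in place of hydrogen on an aromatic carbon, para to a large group, so that phenyl becomes 4-chlorophenyl (chloro in place of hydrogen on an aromatic carbon). With only limits to go on, no step beyond the scatter is expected in this assay. This expectation rests on compound 2 and its limit of > 30000 nM, and any shift that did appear would be expected towards a lower number. The expected change is a number no higher from compound 2 to compound 3 (the limit leaves the size open) here. For compound 3 the estimated value is 30000 nM, with an expected range of 12000 nM to 60000 nM.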

Compound 3, half-maximal inhibitory concentration: > 30000 nM
Compound 3 gave a limit, no number; the forecaster's own chance of this, stated with the estimate: 70%; the middle value sits exactly at the limit.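

In this assay compound 3 gives > 30000 nM, which is a limit and not a number. Among the compounds shown here, compound 2 also gives only a limit, so no step between compound 2 and compound 3 can be read. The compounds shown leave open what swapping phenyl for 4-chlorophenyl does to potency in this assay.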